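This account rests on a few compounds, and the source may have more. Where it says the series, first, only, none or still open, it means among the compounds named here.

Measured in a functional assay on K562 cells (Homo sapiens) for inhibition, read by MTT assay, with a stated time of 5 days; a higher number here means a weaker inhibitor, a lower number a stronger inhibitor:
Compound 1 `COc1ccc(/C=C2\Oc3c(cc(OC)c(OC)c3OC)C2=O)cc1F`: 110 nM
Compound 2 `COc1cc2c(c(OC)c1OC)O/C(=C\c1cc(F)c(OC)c(F)c1)C2=O`: 150 nM
Compound 3 `COc1ccc(-c2cc(=O)c3cc(OC)c(OC)c(OC)c3o2)cc1O`: 40 nM

Compound 3 has the lowest number of the three, and the values of compound 1 and compound 2 both lie beyond the scatter from it. Compound 4 `COc1ccc(-c2cc(=O)c3cc(OC)c(OC)c(OC)c3o2)cc1F` is compound 3 with one change, fluoro in place of hydroxy on an aromatic carbon, ortho to a methoxy group.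

Among the compounds with values here, no measured step makes this exchange. Within the data shown here, the only step available, a 1.4-fold higher number from compound 1 to compound 2 (0.13 log units; within the scatter), adds fluoro in place of hydrogen on a different core, so it bears only loosely on this change. Compound 4 carries the same fluoro and methoxy groups as compound 1, which gives 110 nM, though on the core of compound 3. A small rise in this assay is therefore expected, possibly no larger than the scatter. The step expected is a 1.8-fold higher number from compound 3 to compound 4 (0.24 log units; within the scatter). For compound 4 the estimated value is 70 nM, with an expected range of 25 nM to 200 nM.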

Compound 4, half-maximal inhibitory concentration: 590 nM
Compound 4: middle estimate off by 8.4-fold (0.93 log units), on the low side; the whole stated range lies below it.
By their numbers in this assay, from the lowest: compound 3; then compounds 1 and 2 (each within the scatter of the next); then compound 4.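

In this assay, this exchange on the core of compound 3 gives a 15-fold higher number from compound 3 to compound 4 (1.17 log units; beyond the scatter), so hydroxy cannot be swapped for fluoro at this place, ortho to a methoxy group, without a large loss. The earlier fluoro step, a 1.4-fold higher number from compound 1 to compound 2 (0.13 log units; within the scatter), stayed within the scatter, but it replaced hydrogen on another core, so it says nothing about replacing hydroxy here. Nothing available explains the size of this step.

The compounds shown leave open whether hydroxy itself is needed here or fluoro is what harms, since neither an amine, a plain hydrogen nor a second methoxy group at this place can be compared with them. They also leave open whether hydroxy would give a similar step on the core of compound 1.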